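Phenyl for Pyridin-4-yl on a Weakly Active Pyridine

The compounds below may be only part of what the source reports. "The series", "measured", "known", "first", "only" and "open" are said of these compounds alone.

Measured compounds in an assay on isolated protein for inhibition of DNA topoisomerase 1 (Homo sapiens), with a stated time of 30 min, tested at 100 uM; a higher number here means a stronger effect of the compound at the concentration tested, a lower number a weaker effect:
compound 1 `Oc1cccc(-c2cc(-c3ccc(Cl)cc3)nc(-c3cccs3)c2)c1`: 15.1%
compound 2 `Oc1cccc(-c2cc(-c3ccncc3)nc(-c3ccccc3Cl)c2)c1`: 0%
compound 3 `Oc1cccc(-c2cc(-c3ccc(Cl)cc3)nc(-c3ccccn3)c2)c1`: 30%

Compound 2 stands lowest of the three in this assay. Its nearest neighbour is compound 1, whose value lies above it beyond the scatter; furthest away is compound 3, whose value lies higher still. Compound 4 `Oc1cccc(-c2cc(-c3ccccc3)nc(-c3ccccc3Cl)c2)c1` has not yet been measured. It differs from compound 2 in one place: phenyl in place of pyridin-4-yl on an aromatic carbon.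

Only one measured step exists among these compounds, a number 14.9 percentage points higher from compound 1 to compound 3 (beyond the scatter), and it concerns an exchange at a different place on the shared core, with a 4-chlorophenyl group present rather than a 2-chlorophenyl group. It therefore does not bear directly on the change from compound 2 to compound 4. For the measured compounds named here, the data hold no example of phenyl replacing pyridin-4-yl. Compound 2 is already at the bottom of the range, so a fall beyond the scatter is not possible; a rise beyond it is not supported by any step shown. For compound 4 a step of a number 7 percentage points higher from compound 2 to compound 4 (within the scatter) is expected, within the scatter. Compound 4 is accordingly estimated at 7%, with a range from 0% to 22%.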

Compound 4, a percentage reported as inhibition, at one concentration (the size of the read-out at that concentration, not a potency): 3.2%
Estimate against measurement, compound 4: 3.8 percentage points above, and the stated range covers the measured number.
By their numbers in this assay, from the lowest: compounds 2 and 4 (each within the scatter of the next); then compound 1; then compound 3.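

In this assay, phenyl in place of pyridin-4-yl, on the aromatic carbon next to the ring nitrogen, gives a number 3.2 percentage points higher from compound 2 to compound 4 (within the scatter) for this pair. For the compounds shown here, this is the first reading at this position: the two six-membered aromatic rings differ by one ring nitrogen and its hydrogen-bond acceptor, and the assay does not tell the two compounds apart. No measurement offers any explanation for this result.

On these data alone, with both compounds carrying the 2-chlorophenyl group, it remains open whether the same exchange would read alike alongside a 4-chlorophenyl group. As far as these compounds go, it is also open whether a phenyl ring bearing an amine or a carboxylic acid at this position would give a number beyond the scatter of these two.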